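The compounds below may be only part of what the source reports. "The series", "measured", "known", "first", "only" and "open" are said of these compounds alone.

Compound 1 `CN1C(=O)COC[C@H]1C(=O)NCc1cccc(C(F)(F)F)c1Cl` and compound 2 `Cc1ncccc1N1C[C@@H](C(=O)NCc2cccc(C(F)(F)F)c2Cl)N(C)C1=O` have different ring cores but carry the same amide side chain. In a functional assay on HEK293 cells for antagonist activity at P2X purinoceptor 7 (Homo sapiens) (a higher number here means a weaker inhibitor, a lower number a stronger inhibitor), compound 1 gives 3.98 nM. In this assay compound 2 gives 5.01 nM. Going by the values given here, these two numbers lie within the usual scatter of each other, so the data do not separate compound 2 from compound 1; compound 2 simply sits alongside it, and no step between these two measured compounds has been worked out.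

Compound 3 `CN1C(=O)N(c2nccn2C)C[C@H]1C(=O)NCc1cccc(C(F)(F)F)c1Cl` keeps the core of compound 2 and alters the group on the ring amide nitrogen: 1-methyl-1H-imidazol-2-yl in place of 2-methylpyridin-3-yl on an amide-type nitrogen in a ring. Because compound 1 gives 3.98 nM and compound 2 gives 5.01 nM despite quite different cores, strong inhibition appears to survive changes around the shared side chain, and the group on the ring amide nitrogen seems open to variation. The expectation for compound 3 is therefore a step of a 1.6-fold higher number from compound 2 to compound 3 (0.20 log units; within the scatter) that stays within or only just beyond the scatter, leaning, if anywhere, toward a slightly weaker inhibitor. Compound 3 is estimated at 8 nM, with a range from 2.5 nM to 25 nM.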

Compound 3, half-maximal inhibitory concentration: 3.98 nM
The estimate for compound 3 lay 2.0-fold (0.30 log units) above the measured number; low and high end bracket the measured number.
By their numbers in this assay, from the lowest: compounds 1, 3 and 2 (each within the scatter of the next).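

In this assay, putting 1-methyl-1H-imidazol-2-yl in place of 2-methylpyridin-3-yl on the ring amide nitrogen gives a 1.3-fold lower number from compound 2 to compound 3 (0.10 log units; within the scatter), so the data now hold a direct comparison at this position, and the two groups cannot be told apart by this read-out. The change swaps a six-membered aromatic ring with 1 hetero atom for a five-membered aromatic ring with 2 hetero atoms and adds a hydrogen-bond acceptor to the count, yet for this one pair neither difference appears as a change in the number. Nothing measured here explains why the two groups match.

Both groups shown are aromatic rings that contain nitrogen, so it remains open whether a plain phenyl ring, a bare methyl group, or a group carrying an amine or a carboxylic acid would be tolerated at the same nitrogen. All the compounds shown also carry the same amide side chain, which leaves open how much that part contributes to the number.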